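The source may hold more compounds than are shown below. What is called first, only, known or untested is meant among the compounds shown, and "the series" means these compounds.

Within the data shown here, compound 2 `Cn1cnc2ccc(-c3cnc4[nH]ccc4c3N3CCC4(CCNC4=O)CC3)cc21` is the only compound with a number in an assay on cells for binding affinity to Cyclin-C/Cyclin-dependent kinase 19 (Homo sapiens), read by LanthaScreen (a lower number here means a stronger inhibitor, a higher number a weaker inhibitor), where compound 2 gives 11 nM. Compound 1 `Cn1ncc2cc(-c3cnc4sccc4c3N3CCC4(CCNC4=O)CC3)ccc21` stands without a number, since for compound 1 this assay reads "not determined" (no result reported). Compound 3 `O=C1NCCC12CCN(c1c(-c3ccn4ccnc4c3)cnc3[nH]ccc13)CC2` differs from compound 2 in one place: a group of 9 heavy atoms (7 carbon, 2 nitrogen; one five-membered aromatic ring with 2 hetero atoms, one six-membered aromatic ring with 1 hetero atom) in place of a group of 10 heavy atoms (8 carbon, 2 nitrogen; one five-membered aromatic ring with 2 hetero atoms, one six-membered aromatic ring of carbon only), on an aromatic carbon. Among the measured compounds shown here, no step between measured compounds is known, so the size of this change cannot be read from data. The two groups are alike in ring count and in hetero atom count, so only a small step is expected, if any beyond the scatter; the step from compound 2 to compound 3 is estimated at a 1.4-fold higher number from compound 2 to compound 3 (0.13 log units; within the scatter). Compound 3 is expected to give about 15 nM, within 5 nM to 50 nM.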

Compound 3, half-maximal inhibitory concentration: 68 nM
The estimate for compound 3 lay 4.5-fold (0.66 log units) below the measured number; the measured number lies above the stated range.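

Swapping 1-methyl-1H-benzimidazol-6-yl for a fused group with a nitrogen in its six-membered ring brings a 6.2-fold higher number from compound 2 to compound 3 (0.79 log units; beyond the scatter) in this assay even though the two groups match in ring count and in hydrogen-bond donors and acceptors. This position therefore distinguishes between closely similar fused groups. No available evidence explains the change.

Among these compounds, with only this pair, it remains open whether the ring nitrogen, the missing methyl or the different ring fusion drives the step. A plain phenyl ring or a benzimidazole carrying an amine could show how much of the fused group this position needs.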